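A few compounds are considered here, and "the series" means these few. Any claim that something is new, unique, unknown or untested is made for them only; others in the source may bear on it.

In a functional assay on HT-29 cells (Homo sapiens) for inhibition, read by sulforhodamine B assay, with a stated time of 72 h (on this read-out higher numbers stand for weaker inhibition and lower numbers for stronger inhibition), three compounds have been measured so far. Compound 1 `COc1ccc(C2C(O)C(=O)N2c2cc(OC)c(OC)c(OC)c2)cc1O` gives 463 nM, compound 2 `C=CC1C(=O)N(c2cc(OC)c(OC)c(OC)c2)C1c1ccc(OC)cc1` gives 10 nM, and compound 3 `COc1ccc(C2CC(=O)N2c2cc(OC)c(OC)c(OC)c2)cc1` gives 65 nM, the second highest of the three numbers. Compound 4 `COc1ccc(C2CC(=O)N2c2cc(OC)c(OC)c(OC)c2)cc1O` has not yet been measured. It keeps the structure of compound 3 but has hydroxy in place of hydrogen on an aromatic carbon, ortho to a methoxy group and meta to a large group: hydroxy in place of hydrogen on an aromatic carbon.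

The only measured step among these compounds is a 6.5-fold higher number from compound 2 to compound 3 (0.81 log units; beyond the scatter), with hydrogen in place of vinyl on a saturated ring carbon. That step lies elsewhere in the structure and gives no direct measure of the new hydroxy. Compound 1 carries the same aromatic hydroxy, but it also has a hydroxy on a saturated ring carbon, so its 463 nM does not isolate the aromatic change. For the measured compounds named here, with no measured step at this place, the data leave either direction open, and no step beyond the scatter is expected in this assay. The expected step is a 1.4-fold lower number from compound 3 to compound 4 (0.16 log units; within the scatter). For compound 4 the estimated value is 45 nM, with an expected range from 12 nM to 170 nM.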

Compound 4, half-maximal inhibitory concentration: 521 nM
Compound 4: the middle estimate sits 12-fold (1.06 log units) below what was measured; the measured number lies above the stated range.
By their numbers in this assay, from the lowest: compound 2; then compound 3; then compounds 1 and 4 (each within the scatter of the next).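

In this assay, for the compounds shown here, the added hydroxy, on an aromatic carbon ortho to a methoxy group and meta to a large group, gives the first direct reading of this place, and it moves the number toward weaker inhibition by a step beyond the scatter (an 8.0-fold higher number from compound 3 to compound 4 (0.90 log units; beyond the scatter)). The hydroxy on the saturated ring carbon, which could not be separated from the aromatic hydroxy in compound 1 before, now can be: with the aromatic hydroxy present, its removal leaves the number within the scatter (a 1.1-fold higher number from compound 1 to compound 4 (0.05 log units; within the scatter)), so the aromatic hydroxy alone is enough to reach the range of compound 1. Nothing measured here explains why this aromatic hydroxy weakens inhibition.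

The compounds shown leave open whether this weakening is particular to hydroxy or would also appear with an amine or a fluorine atom on the same aromatic carbon. They also leave open whether the vinyl group of compound 2 would give the same step in a compound that also carries the aromatic hydroxy.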